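Hydroxy to methoxy on compound 1

This account rests on a few compounds, and the source may have more. Where it says the series, first, only, none or still open, it means among the compounds named here.

In a functional assay on KM12 cells (Homo sapiens) for antiproliferative activity, read by sulforhodamine B assay, with a stated time of 48 h (on this read-out lower numbers stand for stronger inhibition of growth and higher numbers for weaker inhibition of growth), compound 1 (`O=C(NCCCNc1cc(-c2cn(-c3ccccc3)nc2-c2cccc(O)c2)ccn1)Nc1ccc(F)cc1`) gives 5790 nM and compound 2 (`O=C(NCCCNc1cc(-c2cn(-c3ccccc3)nc2-c2cccc(O)c2)ccn1)Nc1cccc(C(F)(F)F)c1`) gives 7390 nM. Among the measured compounds shown here, these are the only two measured numbers, and they lie within the scatter of each other, so compound 1 stands level with its single neighbour. Compound 3 (`COc1cccc(-c2nn(-c3ccccc3)cc2-c2ccnc(NCCCNC(=O)Nc3ccc(F)cc3)c2)c1`) keeps the core of compound 1 but carries 3-methoxyphenyl instead of 3-hydroxyphenyl: methyl in place of hydrogen on an oxygen on an aromatic ring. For the measured compounds named here, the one measured step, a 1.3-fold higher number from compound 1 to compound 2 (0.11 log units; within the scatter), changes a different group, so it bears only indirectly on this oxygen. Going by the values given here, no measured pair compares hydroxy with methoxy. In this assay, as far as these compounds go, then, no step beyond the scatter is expected, and the direction stays open. The expected change is a 1.1-fold higher number from compound 1 to compound 3 (0.05 log units; within the scatter). For compound 3 the estimate is 6500 nM, with an expected range from 2500 nM to 16000 nM.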

Compound 3, concentration for total growth inhibition: > 37000 nM
Compound 3: only a limit was reported; the forecaster's own chance of this, stated with the estimate: 10%; at least 5.6-fold (0.75 log units) between middle value and limit.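

Adding one methyl to this oxygen in this assay gives an at least 6.3-fold higher number from compound 1 to compound 3 (0.80 log units; beyond the scatter), so with this core the methoxy compound inhibits growth more weakly than the hydroxy compound, whereas the earlier step at a different group, a 1.3-fold higher number from compound 1 to compound 2 (0.11 log units; within the scatter), showed no such change. The value of compound 3, > 37000 nM, is a limit of the assay and not a number. The step therefore gives only a minimum size, and its full size cannot be read: the limit of > 37000 nM in this assay, at which 1 of the 3 values shown sits.

The compounds shown cannot separate the loss of the hydrogen on this oxygen from the arrival of the methyl. As far as these compounds go, an amine or a fluorine in place of the hydroxy, or a longer chain on the oxygen such as ethyl, would bear on that question, and the same change on compound 2 remains open too.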